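Ethyl in Place of Fluoro on the Anilide of Compound 1

A few compounds are considered here, and "the series" means these few. Any claim that something is new, unique, unknown or untested is made for them only; others in the source may bear on it.

Compound 1 `O=C(Nc1cccc(F)c1)c1cncc(N2CC3CC(C2)N3)c1` — 0.044 nM
Compound 2 `O=C(c1cncc(N2CC3CC(C2)N3)c1)N1CCCc2ccccc21` — 0.196 nM
Compound 3 `O=C(c1cncc(N2CC3CC(C2)N3)c1)N1CCc2ccccc2C1` — 0.031 nM

In an assay on membranes from Cerebral cortex for displacement of a labelled ligand from Neuronal acetylcholine receptor; alpha4/beta2 (Rattus norvegicus) (on this read-out lower numbers stand for stronger inhibition and higher numbers for weaker inhibition), compound 1 gives 0.044 nM, the second highest of the three numbers. Compound 3 gives 0.031 nM, which lies within the scatter of compound 1, while compound 2 gives 0.196 nM, beyond the scatter and the furthest from compound 1. Compound 4 `CCc1cccc(NC(=O)c2cncc(N3CC4CC(C3)N4)c2)c1` differs from compound 1 by ethyl in place of fluoro on an aromatic carbon. Going by the values given here, no measured pair shows this same change, so nothing among the three compounds fixes its size. A small step toward higher numbers, about at the edge of the scatter, is expected; the estimated step is a 1.8-fold higher number from compound 1 to compound 4 (0.26 log units; within the scatter). Compound 4 is therefore expected to give about 0.08 nM, with a range from 0.02 nM to 0.3 nM.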

Compound 4, inhibition constant: 1.3 nM
For compound 4 the middle estimate is 16-fold (1.21 log units) below the measured one; the whole stated range lies below it.
By their numbers in this assay, from the lowest: compounds 3 and 1 (each within the scatter of the next); then compound 2; then compound 4.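

In this assay the change from 3-fluorophenyl to 3-ethylphenyl is a large one (a 30-fold higher number from compound 1 to compound 4 (1.47 log units; beyond the scatter)), so this place on the aromatic ring, meta to a large group, is far from indifferent to which group it carries. Going by these compounds alone, the earlier compounds showed no change at this place, and this pair is the first sign of how much it can matter. Nothing at hand explains why the number rises so far. On these data alone, whether a methyl, a chlorine or an amine on this carbon would lie nearer compound 1 or compound 4 remains open.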